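Bromo to hydrogen on the phenoxy group of compound 3

This account rests on a few compounds, and the source may have more. Where it says the series, first, only, none or still open, it means among the compounds named here.

In a functional assay (aorta) with Oryctolagus cuniculus as the target (a lower number here means tighter binding, a higher number weaker binding), compound 3 (`Fc1ccc(C(c2ccc(F)cc2)C2CCN(CCCOc3ccc(Br)cc3)CC2)cc1`) gives 1.59 nM as the lowest of three measured numbers, with compound 1 (`COc1cc(C(C)O)ccc1OCCCN1CCC(C(c2ccc(F)cc2)c2ccc(F)cc2)CC1`) at 10 nM and compound 2 (`NC(=O)c1ccc(OCCCN2CCC(C(c3ccc(F)cc3)c3ccc(F)cc3)CC2)cc1`) at 31.6 nM in the same test. Compound 4 (`Fc1ccc(C(c2ccc(F)cc2)C2CCN(CCCOc3ccccc3)CC2)cc1`) has hydrogen in place of bromo on an aromatic carbon, para to a large group (hydrogen in place of bromo on an aromatic carbon). The nearest measured change, also on an aromatic carbon, is bromo in place of carbamoyl (a 20-fold lower number from compound 2 to compound 3 (1.30 log units; beyond the scatter)), a large step. Putting 4-bromophenyl in place of 4-(1-hydroxyethyl)-2-methoxyphenyl (a 6.3-fold lower number from compound 1 to compound 3 (0.80 log units; beyond the scatter)) is a modest step, as is 4-carbamoylphenyl in that place (a 3.2-fold higher number from compound 1 to compound 2 (0.50 log units; beyond the scatter)). For the measured compounds named here, no measured pair compares bromo with hydrogen directly. Compound 3 at 1.59 nM carries the bromo and holds the lowest number, so a modest move to a higher number is expected in this assay on losing it. The estimated step is modest (a 3.1-fold higher number from compound 3 to compound 4 (0.50 log units; beyond the scatter)) rather than large. Compound 4 is estimated at 5 nM with an expected range from 1.6 nM to 16 nM in this test.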

Compound 4, dissociation constant: 1.59 nM
Compound 4: the middle estimate sits 3.1-fold (0.50 log units) above what was measured; the measured number lies below the stated range.
By their numbers in this assay, from the lowest: compounds 3 and 4 (each within the scatter of the next); then compound 1; then compound 2.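

In this assay, for the compounds shown here, taking the bromo off the aromatic carbon, para to a large group, changes nothing visible (no change at the digits printed from compound 3 to compound 4 (within the scatter)), which the earlier compounds, all carrying a group at that place, could not show. The lower numbers therefore do not need the bromo, since the plain phenyl also stands well clear of carbamoyl (a 20-fold lower number from compound 2 to compound 4 (1.30 log units; beyond the scatter)) and of 4-(1-hydroxyethyl)-2-methoxyphenyl (a 6.3-fold lower number from compound 1 to compound 4 (0.80 log units; beyond the scatter)). Nothing at hand explains why bromo and hydrogen read alike.

The compounds shown leave open whether other small atoms at this place, such as chloro or fluoro, would also read like bromo and hydrogen. They also leave open whether an amine or a carboxylic acid there would move the number as far as carbamoyl does.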